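The source may hold more compounds than are shown below. What is called first, only, known or untested is meant among the compounds shown, and "the series" means these compounds.

Of the compounds shown here, three have been tested so far in a functional assay on HL-60 cells (Homo sapiens) for antiproliferative activity; on this read-out higher numbers stand for weaker inhibition and lower numbers for stronger inhibition. Going by the values given here, compound 1 `COc1ccc(O)c2c(O)ccnc12` gives 17700 nM, the only exact number available. Compound 2 `COc1ccc(O)c2c(=O)ccn(C)c12` gives > 30000 nM, which is a limit of the assay and not a number. Compound 3 `COc1cc2c(c(O)c1OC)c(=O)ccn2C` gives > 30000 nM, which is also a limit and not a number. Compound 3 therefore has no exact place on the scale and stands at the limit of > 30000 nM in this assay, at which 2 of the 3 values shown sit.

The next compound, compound 4 `COc1cc2c(=O)ccn(C)c2cc1OC`, comes from compound 3 by a single change: hydrogen in place of hydroxy on an aromatic carbon. Among the compounds with values here, no two measured compounds differ in just one place, so no measured step shows what such a change does in this assay. The expectation can rest only on compound 3, whose reading of > 30000 nM is a limit. No step beyond the usual scatter is expected in either direction, and the assay may well report only a limit again. The expected size of the change is a step that the limit leaves unreadable from compound 3 to compound 4. For compound 4 the estimated value is 35000 nM, with an expected range from 15000 nM to 80000 nM.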

Compound 4, half-maximal inhibitory concentration: > 30000 nM
Compound 4: only a limit was reported; the forecaster's own chance of this, stated with the estimate: 75%; the middle value lies beyond the limit too.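

Compound 3 and compound 4 both gave readings that are limits of the assay and not numbers, so no step between them can be read: the limit of > 30000 nM in this assay, at which 3 of the 4 values shown sit.

The compounds shown leave open whether replacing the hydroxy with hydrogen changes anything in this assay, and how far past the limit either compound truly lies.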